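Adding a chloro group to compound 2

This account rests on a few compounds, and the source may have more. Where it says the series, first, only, none or still open, it means among the compounds named here.

In a functional assay on the whole organism for antagonist activity, with Mus musculus as the target, in the maximal electroshock model (on this read-out lower numbers stand for an effect already at smaller amounts and higher numbers for an effect only at larger amounts of compound), compound 2 `COC(=O)NC1=NC(c2ccccc2)CN1C` gives 107 mg/kg, the second highest of three numbers, and it lies within the scatter of the other two. One of these is compound 3 `CCN1CC(c2ccccc2)N=C1NC(=O)OC`, which gives 66 mg/kg. Compound 4 `COC(=O)NC1=NC(c2ccc(Cl)cc2)CN1C` has not yet been measured. It differs from compound 2 by one change, chloro in place of hydrogen on an aromatic carbon, para to a large group.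

Among the measured compounds shown here, the only measured step between close relatives, a 1.6-fold lower number from compound 2 to compound 3 (0.21 log units; within the scatter), is a different change, methyl in place of hydrogen on a saturated chain carbon, so it offers no direct guide. The nearest evidence is compound 1 `COC(=O)NC1=NC(c2ccc(Cl)cc2)CN1`, which also carries chloro but lacks the methyl of compound 2. Compound 1 gives about 200 mg/kg, still within the scatter of compound 2, so no step beyond the scatter is expected in this assay. The estimate is a 1.1-fold lower number from compound 2 to compound 4 (0.03 log units; within the scatter). For compound 4 the expected value is 100 mg/kg, with an estimated range from 45 mg/kg to 220 mg/kg.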

Compound 4, dose for half-maximal effect: 66 mg/kg
Estimate against measurement, compound 4: 1.5-fold (0.18 log units) above; the measured number falls inside the stated range.
By their numbers in this assay, from the lowest: compounds 3, 4, 2 and 1 (each within the scatter of the next, the first and the last beyond it).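

In this assay, chloro in place of hydrogen on an aromatic carbon, para to a large group, gives a 1.6-fold lower number from compound 2 to compound 4 (0.21 log units; within the scatter), so with the methyl present on the amine nitrogen in the ring, this change stays inside the usual variation between repeated measurements. With chloro kept in place, methyl in place of hydrogen on that ring nitrogen gives a 3.0-fold lower number from compound 1 to compound 4 (0.48 log units; beyond the scatter), a modest step and the only one shown here that lies beyond the scatter. Nothing at hand explains why either step has the size it does.

As far as these compounds go, whether the ring nitrogen would tolerate a longer chain such as propyl remains open. From the compounds shown here alone, it is also open whether fluoro or methoxy on the same aromatic carbon would behave like chloro.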